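The source may report more compounds than this note shows. Statements on the series, on what has been measured and on what is new or still open speak of the compounds shown alone.

Within the data shown here, compound 2 `COc1cc(-c2cc(/C=C/C(=O)c3ccccc3)nc3cc(-c4ccccc4)nn23)cc(OC)c1OC` gives 15800 nM in a functional assay on MDA-MB-231 cells (Homo sapiens) for antiproliferative activity, read by MTT assay, with a stated time of 24 h (a lower number here means a stronger inhibitor, a higher number a weaker inhibitor), the smaller of the two numbers known, though compound 1 `COc1ccc(-c2cc(C(=O)/C=C/c3ccc(C)cc3)nc3cc(-c4ccccc4)nn23)cc1OC` gives 22600 nM in this assay, a gap that stays within the usual scatter. Compound 3 `COc1cc(-c2cc(C(=O)/C=C/c3ccc(C)cc3)nc3cc(-c4ccccc4)nn23)cc(OC)c1OC` has not yet been measured in this assay; it differs from compound 2 by (2-(4-methylphenyl)ethenyl)carbonyl in place of 2-benzoylethenyl on an aromatic carbon. Among the measured compounds shown here, no step between measured compounds that differ in one place exists, so no size can be taken from the data. The expected step of a 1.1-fold higher number from compound 2 to compound 3 (0.06 log units; within the scatter) is none beyond the scatter. Compound 3 is estimated at 18000 nM, in a range from 7000 nM to 45000 nM.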

Compound 3, half-maximal inhibitory concentration: 18600 nM
Compound 3: middle estimate off by 1.0-fold (0.01 log units), on the low side; the range from low to high includes it.
By their numbers in this assay, from the lowest: compounds 2, 3 and 1 (each within the scatter of the next).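

In this assay, placing (2-(4-methylphenyl)ethenyl)carbonyl in place of 2-benzoylethenyl on this aromatic carbon, next to the ring nitrogen, gives a 1.2-fold higher number from compound 2 to compound 3 (0.07 log units; within the scatter), so this change leaves the number unmoved beyond the scatter. Methoxy in place of hydrogen on an aromatic carbon gives a 1.2-fold lower number from compound 1 to compound 3 (0.08 log units; within the scatter), which is likewise no shift beyond the scatter. Nothing measured here bears on these results. The compounds shown leave open whether an amine or a carboxylic acid on the aromatic ring of this side chain would shift the number beyond the scatter.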